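Compound 3: fluoro in place of methyl

The source may hold more compounds than are shown below. What is called first, only, known or untested is meant among the compounds shown, and "the series" means these compounds.

Compound 1 `Cc1cccc(C(=O)N[C@@H]2C(=O)Nc3c(c(C)nn3C3CCCC3)[C@@H]2c2ccc(F)cc2)c1` gives 0.5 h
Compound 2 `Cc1ccc([C@H]2c3c(C)nn(-c4ccccc4)c3NC(=O)[C@H]2NC(=O)c2cccc(C)c2)cc1` gives 0.3 h

Only these two compounds have been measured so far. In an ADME assay on microsomes (Mus musculus) for metabolic stability, tested at 0.8 uM (on this read-out lower numbers stand for a shorter-lived compound and higher numbers for a longer-lived compound), compound 2 gives 0.3 h and stands within the usual scatter of compound 1 at 0.5 h on this scale, so the two numbers cannot be told apart.

The next compound, compound 3 `Cc1cccc(C(=O)N[C@@H]2C(=O)Nc3c(c(C)nn3-c3ccccc3)[C@@H]2c2ccc(F)cc2)c1`, departs from compound 2 in a single place, where 4-methylphenyl becomes 4-fluorophenyl: fluoro in place of methyl on an aromatic carbon. In words, this is fluoro in place of methyl on an aromatic carbon.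

Going by the values given here, no two measured compounds differ in one place only, so no measured step shows what this swap does in this assay. The expectation therefore rests on the narrow range set by compound 2 at 0.3 h and compound 1 at 0.5 h, and it is a cautious one. A small move towards a longer life is expected, but nothing beyond the scatter. The estimated change is a 1.3-fold higher number from compound 2 to compound 3 (0.12 log units; within the scatter) and it remains an expectation until measured. For compound 3 the expected half-life is 0.4 h (estimated range 0.2 h to 0.9 h).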

Compound 3, half-life: 1.1 h
Compound 3: middle estimate off by 2.8-fold (0.44 log units), on the low side; measured number above the stated range.
By their numbers in this assay, from the lowest: compounds 2 and 1 (each within the scatter of the next); then compound 3.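

In this assay, going by these compounds alone, fluoro in place of methyl on an aromatic carbon, para to a large group, gives a 3.7-fold higher number from compound 2 to compound 3 (0.56 log units; beyond the scatter) as the first step at this position that can be read on its own. It shows that this one-atom change is enough to lengthen the half-life beyond the scatter, which the earlier pair could not show. The 4-fluorophenyl group stays in place in the second step, where phenyl in place of cyclopentyl on an aromatic nitrogen gives a 2.2-fold higher number from compound 1 to compound 3 (0.34 log units; beyond the scatter) and so shows that this second position also affects the half-life, with nothing measured here to explain either rise.

As far as these compounds go, each change has been seen only once, on one background, so it remains open whether the fluoro step would hold with cyclopentyl on the nitrogen. From the compounds shown here alone, it also remains open whether the gain needs fluoro itself or only the absence of methyl, which a plain hydrogen, a chloro or a methoxy group on that same carbon would help to separate.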